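The source may report more compounds than this note shows. Statements on the series, on what has been measured and on what is new or still open speak of the compounds shown alone.

Working notes on the series in a functional assay on A2780 cells (Homo sapiens) for antiproliferative activity, read by MTT assay, with a stated time of 3 days; a lower number here means a stronger inhibitor, a higher number a weaker inhibitor. Of the compounds shown here, three have been measured: compound 1 `CC1=CSC(O)(c2ccc(C)cc2)c2noc(=O)n21`, compound 3 `O=c1onc2n1C=CSC2(O)c1ccccc1` and compound 2 `CC1=CSC(O)(c2cccc([N+](=O)[O-])c2)c2noc(=O)n21`, the last bearing a nitro group on the six-membered aromatic ring. In this assay compound 1 returns only a limit of the assay, > 100000 nM. Compound 3 likewise gives a limit in this assay, > 100000 nM. Among the measured compounds shown here, compound 2 is the single member with a number in this assay, 159000 nM, and so stands alone among the three, the other two sitting at the limit of > 100000 nM in this assay, at which 2 of the 3 values shown sit. All activity seen so far is therefore weak.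

Compound 4 `CC1=CSC(O)(c2cccc(Cl)c2)c2noc(=O)n21` differs from compound 2 by chloro in place of nitro on an aromatic carbon. For the measured compounds named here, no measured pair differs in one place, so no measured step indicates how large this change might be. The expected step is a 1.1-fold lower number from compound 2 to compound 4 (0.03 log units; within the scatter), essentially none beyond the usual scatter, with a real chance that only a limit is reported. Compound 4 is expected to give about 150000 nM in this assay, in the range 60000 nM to 400000 nM.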

Compound 4, half-maximal inhibitory concentration: > 100000 nM
Compound 4 ended at the assay's limit; the forecaster's own chance of this, stated with the estimate: 50%; the middle value does not contradict the limit.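

No step can be read from compound 2 to compound 4, as compound 4 returns only a limit in this assay: the limit of > 100000 nM in this assay, at which 3 of the 4 values shown sit.

The compounds shown leave open whether chloro in place of nitro on the aromatic carbon changes activity in this assay at all.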